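This account rests on a few compounds, and the source may have more. Where it says the series, first, only, none or still open, it means among the compounds named here.

Measured so far in a functional assay on ACHN cells (Homo sapiens) for cytotoxicity, read by sulforhodamine B assay, with a stated time of 72 h; on this read-out lower numbers stand for stronger inhibition of growth and higher numbers for weaker inhibition of growth:
compound 1, `O=C(Nc1cc(C(F)(F)F)cc(C(F)(F)F)c1)C1CCc2ccccc2N1C(=O)c1ccc(Cl)cc1`, gives 2570 nM.
compound 2, `O=C(Nc1ccccc1O)C1CCc2ccccc2N1`, gives 3990 nM.
compound 3, `CC(=O)N1c2ccccc2CCC1C(=O)Nc1cc(C(F)(F)F)cc(C(F)(F)F)c1`, gives > 70000 nM.

The value for compound 3 is not a number but a limit of the assay, (the limit of > 70000 nM in this assay, at which 1 of the 3 values shown sits). Compound 3 therefore stands at the weak end of what has been measured, with no number of its own to compare. For the measured compounds named here, the one measured step that reaches compound 3 is an at least 27-fold higher number from compound 1 to compound 3 (1.43 log units; beyond the scatter). Going by the values given here, compound 2 carries no comparable step and only shows its own value.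

The next compound is compound 4, `O=C(Nc1cc(C(F)(F)F)cc(C(F)(F)F)c1)C1CCc2ccccc2N1C(=O)c1cccc(Cl)c1`. Its difference from compound 3 is 3-chlorophenyl in place of methyl on a carbonyl carbon. This is close to the reverse of the step from compound 1 to compound 3, only with the chlorine on a different position of the phenyl ring, and that measured step was large and beyond the scatter. A step of similar size in the opposite direction is therefore expected, bringing compound 4 back near where compound 1 stands. The expected step in this assay is an at least 20-fold lower number from compound 3 to compound 4 (1.30 log units; beyond the scatter). For compound 4 the estimate is 3500 nM, within the range 900 nM to 20000 nM.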

Compound 4, concentration for 50% growth inhibition: 813 nM
Compound 4: the middle estimate sits 4.3-fold (0.63 log units) above what was measured; measured number below the stated range.
By their numbers in this assay, from the lowest: compound 4; then compounds 1 and 2 (each within the scatter of the next). At a limit, above all of these: compound 3.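

In this assay, the carbonyl carbon on the ring nitrogen now has two chlorophenyl groups to compare, and the place of the chlorine on the phenyl ring changes the read-out: 3-chlorophenyl in place of 4-chlorophenyl gives a 3.2-fold lower number from compound 1 to compound 4 (0.50 log units; beyond the scatter). Methyl replaced by 3-chlorophenyl gives an at least 86-fold lower number from compound 3 to compound 4 (1.93 log units; beyond the scatter), which runs opposite to the earlier loss on going from 4-chlorophenyl to methyl, so among the three compounds at this place, both chlorophenyl compounds read lower than the methyl compound. Compound 3 stands at a limit, so this step gives a bound and not a size: the limit of > 70000 nM in this assay, at which 1 of the 4 values shown sits.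

The compounds shown leave open whether a phenyl ring is needed on this carbonyl carbon, or whether a cyclohexyl group, a longer chain such as butyl, or an unsubstituted phenyl would serve as well, and whether chlorine itself matters compared with a methoxy group or a nitrile on the same ring. Compound 2 differs from the others in more than one place, so its value cannot yet be tied to any single change in the series.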